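An Aryl Group Returns to the Ring Nitrogen

This account rests on a few compounds, and the source may have more. Where it says the series, first, only, none or still open, it means among the compounds named here.

Among the compounds with values here, in a functional assay on HepG2 cells (Homo sapiens) for antiproliferative activity, read by MTT assay, with a stated time of 72 h (on this read-out lower numbers stand for stronger inhibition and higher numbers for weaker inhibition), compound 3 (`CC(C)N1C(=O)COc2ccc(-c3cnc(Cl)c(NS(=O)(=O)c4ccc(F)cc4)c3)cc21`) gives 21500 nM as the only actual number of the set. Compound 1 (`O=C1COc2ccc(-c3cnc(Cl)c(NS(=O)(=O)c4ccc(F)cc4)c3)cc2N1C1CCCCC1`) gives only a limit (> 40000 nM) here. Compound 2 (`COc1ccc(N2C(=O)COc3ccc(-c4cnc(Cl)c(NS(=O)(=O)c5ccc(F)cc5)c4)cc32)cc1`) also gives only a limit (> 40000 nM) here. Compound 4 (`O=C1COc2ccc(-c3cnc(Cl)c(NS(=O)(=O)c4ccc(F)cc4)c3)cc2N1c1ccc(F)cc1`) carries 4-fluorophenyl in place of isopropyl on an amide-type nitrogen in a ring. The step that removes 4-methoxyphenyl (an at least 1.8-fold lower number from compound 2 to compound 3 (0.26 log units; that floor lies within the scatter)) bears most closely on this change, and the step that removes cyclohexyl (an at least 1.8-fold lower number from compound 1 to compound 3 (0.26 log units; that floor lies within the scatter)) reads alike, both with floors inside the scatter. A modest rise in this assay is therefore expected, with a real chance of landing on the limit (the limit of > 40000 nM in this assay, at which 2 of the 3 values shown sit) instead of a number. The estimate is a small step (a 1.8-fold higher number from compound 3 to compound 4 (0.25 log units; within the scatter)) toward weaker inhibition. Compound 4 is estimated at 38000 nM within an expected range (18000 nM to 80000 nM).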

Compound 4, half-maximal inhibitory concentration: > 40000 nM
Compound 4: only a limit was reported; the forecaster's own chance of this, stated with the estimate: 55%; middle value at least 1.0-fold (0.02 log units) away from the limit.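

In this assay, 4-fluorophenyl on this amide-type nitrogen gives an at least 1.8-fold higher number from compound 3 to compound 4 (0.26 log units; that floor lies within the scatter), so a second aryl group also fails to give a number, though this floor alone does not separate the two compounds. The steps that join compound 4 to the cyclohexyl and 4-methoxyphenyl compounds cannot be read, each joining two limits. Isopropyl remains the only group here with an actual number, and the set now gathers at the ceiling: the limit of > 40000 nM in this assay, at which 3 of the 4 values shown sit.

As far as these compounds go, how far any of these groups lies past that limit stays open. Also open, from the compounds shown here alone, is whether a methyl group, or a longer chain ending in an amine or a carboxylic acid, would give a number on this nitrogen.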